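Cytotoxicity notes on a coumarin-ether series, compounds 1 to 3

The source may report more compounds than this note shows. Statements on the series, on what has been measured and on what is new or still open speak of the compounds shown alone.

Measured so far:
compound 1 `Cc1c(Cc2ccc(C(F)(F)F)cc2)c(=O)oc2cc(OCC(O)CN3CCC(C(N)=O)CC3)ccc12` with 89300 nM
compound 2 `Cc1noc(C)c1-c1ccc(Cc2c(C)c3ccc(OCC(O)CN4CCC(C(N)=O)CC4)cc3oc2=O)cc1` with 36900 nM

Among the measured compounds shown here, compound 2 holds the lowest of the two numbers in an ADME assay on A549 cells (Homo sapiens) for cytotoxicity, read by CellTiter-Glo; on this read-out lower numbers stand for higher toxicity in this test and higher numbers for lower toxicity in this test; compound 1 stands nearest, and the step of a 2.4-fold lower number from compound 1 to compound 2 (0.38 log units; beyond the scatter) is the only measured change in the set. Compound 3 `Cc1c(Cc2ccc(-c3ccc(F)cc3)cc2)c(=O)oc2cc(OCC(O)CN3CCC(C(N)=O)CC3)ccc12` is not yet measured. It differs from compound 2 by 4-fluorophenyl in place of 3,5-dimethyl-1,2-oxazol-4-yl on an aromatic carbon. For the measured compounds named here, the one measured step bears only loosely on this change: it swapped trifluoromethyl for a five-membered aromatic ring, whereas here one aromatic ring gives way to another of the same heavy-atom count, so a smaller shift than the step from compound 1 to compound 2 is the more likely outcome. Compound 3 is therefore expected to show a step of a 1.2-fold lower number from compound 2 to compound 3 (0.09 log units; within the scatter), within the usual scatter. The estimate for compound 3 in this assay is 30000 nM, with a range from 12000 nM to 75000 nM.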

Compound 3, half-maximal cytotoxic concentration: 19300 nM
Compound 3: middle estimate off by 1.6-fold (0.19 log units), on the high side, within the range that was stated.
By their numbers in this assay, from the lowest: compounds 3 and 2 (each within the scatter of the next); then compound 1.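

In this assay, 4-fluorophenyl in place of 3,5-dimethyl-1,2-oxazol-4-yl on this aromatic carbon gives a 1.9-fold lower number from compound 2 to compound 3 (0.28 log units; within the scatter), so at equal heavy-atom count the five-membered aromatic ring with 2 hetero atoms and the six-membered aromatic ring of carbon only are not told apart here. Measured against trifluoromethyl, 4-fluorophenyl gives a 4.6-fold lower number from compound 1 to compound 3 (0.67 log units; beyond the scatter), and this step runs the same way as a 2.4-fold lower number from compound 1 to compound 2 (0.38 log units; beyond the scatter), so both ring-bearing compounds stand apart from compound 1 on the same side. No measurement at hand offers an explanation for these steps.

From the compounds shown here alone, with only these three groups at this position, it remains open whether any aromatic ring there gives the same result. An amine or a carboxylic acid on the distal ring would test how far the pattern extends.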